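From (4-methoxyphenyl)amino to piperidin-1-yl on the carbonyl

The source may report more compounds than this note shows. Statements on the series, on what has been measured and on what is new or still open speak of the compounds shown alone.

In a functional assay on KB cells (Homo sapiens) for antiproliferative activity, read by sulforhodamine B assay, with a stated time of 3 days (on this read-out higher numbers stand for weaker inhibition of growth and lower numbers for stronger inhibition of growth), compound 1 (`COc1ccc(N2CCN(C)CC2)cc1Nc1ncc(F)c(Nc2ccc(F)cc2)n1`) gives 960 nM as a measured number. Compound 2 (`O=C(Nc1ccc(C(F)(F)F)cc1)c1cccc(Nc2ncc(F)c(Nc3ccc(F)cc3)n2)c1`) gives > 10000 nM as a limit of the assay and not a number. Compound 3 (`COc1ccc(NC(=O)c2cccc(Nc3ncc(F)c(Nc4ccc(F)cc4)n3)c2)cc1`) gives > 10000 nM as a limit too. Compound 3 thus has no exact place on the scale, only the limit of > 10000 nM in this assay, at which 2 of the 3 values shown sit, and nothing finer.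

Compound 4 (`O=C(c1cccc(Nc2ncc(F)c(Nc3ccc(F)cc3)n2)c1)N1CCCCC1`), not yet measured, carries piperidin-1-yl in place of (4-methoxyphenyl)amino on a carbonyl carbon. Going by the values given here, the one measured step that touches compound 3 is a step that the two limits leave unreadable from compound 2 to compound 3 and it concerns another group, so it hands over no size for this change. Among the compounds with values here, no measured step bears directly on the change, and the data favour no direction. The expectation in this assay is therefore no step beyond the scatter, and a number no higher from compound 3 to compound 4 (the limit leaves the size open) is the estimated step on that reading. With compound 3 standing at > 10000 nM as a limit, compound 4 is expected to stay close to that limit, and quite possibly to be reported only as a limit itself. The estimated value for compound 4 is 10000 nM (expected range 3000 nM to 30000 nM).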

Compound 4, concentration for 50% growth inhibition: 14800 nM
Estimate against measurement, compound 4: 1.5-fold (0.17 log units) below, within the range that was stated.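

No new step can be read for compound 4 against compound 2 or compound 3 in this assay, as each of those two compounds is reported only as a limit of the assay: the limit of > 10000 nM in this assay, at which 2 of the 4 values shown sit.

The compounds shown leave open how far apart compound 2, compound 3 and compound 4 truly stand, and whether exchanging the group on the carbonyl carbon changes growth inhibition at all.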